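The source may hold more compounds than are shown below. What is called first, only, known or untested is meant among the compounds shown, and "the series" means these compounds.

Measured so far in an ADME assay on microsomes from liver (Rattus norvegicus, strain Sprague-Dawley) for metabolic stability, read by HPLC, using NADPH, with stated times of 5 min and 60 min, tested at 10 uM; a lower number here means that the compound disappears faster, a higher number that the compound lasts longer

Compound 1 `CC(C)S(=O)(=O)Nc1ccc(CNC(=O)c2ccc(C(C)(C)C)cc2)c(Cl)c1` gives 0.983 h
Compound 2 `CC(C)(C)c1ccc(C(=O)NCc2ccc(NS(C)(=O)=O)cc2F)cc1` gives 0.483 h
Compound 3 `CS(=O)(=O)Nc1ccc(CNC(=O)c2ccc(C34CC(C3)C4)cc2)c(Cl)c1` gives 1.35 h

Compound 3 (1.35 h) lies within the scatter of compound 1 (0.983 h), and it lasts longer than compound 2 (0.483 h) by a margin beyond the scatter. Compound 4 (`CN(C)c1ccc(C(=O)NCc2ccc(NS(C)(=O)=O)cc2Cl)cc1`) keeps the rest of compound 3 and exchanges one group (a group of 3 heavy atoms (2 carbon, 1 nitrogen; no ring) in place of a group of 5 heavy atoms (5 carbon; 2 four-membered non-aromatic rings of carbon only), on an aromatic carbon), on an aromatic carbon para to a large group. Among the measured compounds shown here, no two measured compounds differ in only one place, so the numbers give no direct guide to this exchange. The expectation rests on the structural change alone, and it is a moderate fall in this assay, with an expected size of (a 2.3-fold lower number from compound 3 to compound 4 (0.35 log units; beyond the scatter)). Compound 4 is estimated at 0.6 h (range 0.25 h to 1.3 h).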

Compound 4, half-life: 0.883 h
Beside the measured number, compound 4's estimate is 1.5-fold (0.17 log units) below it; low and high end bracket the measured number.
By their numbers in this assay, from the lowest: compounds 2, 4, 1 and 3 (each within the scatter of the next, the first and the last beyond it).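

Para to a large group on the aromatic carbon, dimethylamino takes the place of the carbon group with two four-membered rings, and this assay shows a 1.5-fold lower number from compound 3 to compound 4 (0.18 log units; within the scatter). Among the compounds shown here, this is the first comparison here in which only one place differs, and it does not separate these two groups, although they differ in size, ring content and nitrogen. No measurement here gives a reason for this result.

Going by these compounds, how a carboxylic acid or a longer carbon chain would fare at this position stays open. On these data alone, it is also open whether this exchange would give a similar step on a different core.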